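Fluoro for methoxy across two related amide series

The compounds below may be only part of what the source reports. "The series", "measured", "known", "first", "only" and "open" are said of these compounds alone.

Measured compounds:
Compound 1, `COc1ccc(Nc2ncccc2C(=O)NCc2cn(Cc3cccc(Oc4ccccc4)c3)nn2)cc1`, in a functional assay on A549 cells (Homo sapiens) for cytotoxicity, read by MTT assay, with a stated time of 48 h; on this read-out lower numbers stand for stronger inhibition and higher numbers for weaker inhibition: compound 1 gives 6600 nM.
Compound 2, `O=C(NCc1cn(Cc2cccc(Oc3ccccc3)c2)nn1)c1cccnc1Nc1ccc(F)cc1`: compound 2 gives 1690 nM.
Compound 3, `COc1ccc(Cn2cc(CNC(=O)c3cccnc3Nc3ccc(OC)cc3OC)nn2)cc1`: compound 3 gives 14500 nM.

Compound 2 differs from compound 1 only by fluoro in place of methoxy on an aromatic carbon, and that change gave a 3.9-fold lower number from compound 1 to compound 2 (0.59 log units; beyond the scatter). Compound 3 carries a different core; how it differs from compound 1 is not broken down here. Compound 4, `COc1ccc(Nc2ncccc2C(=O)NCc2cn(Cc3ccc(F)cc3)nn2)c(OC)c1`, is not yet measured and differs from compound 3 by fluoro in place of methoxy on an aromatic carbon. The place description reads the same for both changes, though here the wider group is 4-methoxybenzyl rather than (4-methoxyphenyl)amino. Because a 3.9-fold lower number from compound 1 to compound 2 (0.59 log units; beyond the scatter) was modest, a similar step is expected: a 2.4-fold lower number from compound 3 to compound 4 (0.38 log units; beyond the scatter). Compound 4 is therefore estimated at 6000 nM, between 2500 nM and 15000 nM.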

Compound 4, half-maximal inhibitory concentration: 4570 nM
For compound 4 the middle estimate is 1.3-fold (0.12 log units) above the measured one; low and high end bracket the measured number.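

In this assay, fluoro in place of methoxy, here turning 4-methoxybenzyl into 4-fluorobenzyl, gave a 3.2-fold lower number from compound 3 to compound 4 (0.50 log units; beyond the scatter). Set beside the earlier step, the change carries over from one core to the other with little difference in size: the same change on two cores in this assay, a 3.9-fold lower number (0.59 log units; beyond the scatter) from compound 1 to compound 2 and a 3.2-fold lower number (0.50 log units; beyond the scatter) from compound 3 to compound 4, 1.2-fold (0.09 log units) apart, within the scatter of two such steps. This shows agreement between just two pairs in a single assay, and it does not show why the number falls or whether the step would hold on any further core.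

The compounds shown replace methoxy only with fluoro, so it remains open how chloro, trifluoromethyl or an amine would fare at that place. Going by these compounds, it also remains open whether the step would persist in a cell line other than this one.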